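Swapping Out Morpholin-4-yl on a Thiocarbonyl Carbon

The source may report more compounds than this note shows. Statements on the series, on what has been measured and on what is new or still open speak of the compounds shown alone.

Measured in a functional assay on MGC-803 cells (Homo sapiens) for inhibition, read by CCK-8 assay, with a stated time of 48 h; a lower number here means a stronger inhibitor, a higher number a weaker inhibitor:
Compound 1 `COc1ccc(CN(C(=O)CSc2nc3ccccc3o2)c2cc(OC)c(OC)c(OC)c2)cc1`: 450 nM
Compound 2 `COc1ccc(CN(C(=O)CSC(=S)N2CCN(C(C)=O)CC2)c2cc(OC)c(OC)c(OC)c2)cc1`: 480 nM
Compound 3 `COc1ccc(CN(C(=O)CSC(=S)N2CCOCC2)c2cc(OC)c(OC)c(OC)c2)cc1`: 2370 nM

Of these three, compound 3 has the highest number at 2370 nM, which makes it the weakest inhibitor of the set. Compound 4 `COc1ccc(CN(C(=O)CSC(=S)N2CCc3cc(Br)ccc32)c2cc(OC)c(OC)c(OC)c2)cc1` has 5-bromo-2,3-dihydro-1H-indol-1-yl in place of morpholin-4-yl on a thiocarbonyl carbon. Among the compounds with values here, two measured steps bear on this change. With morpholin-4-yl in place of 4-acetylpiperazin-1-yl, the result is a 4.9-fold higher number from compound 2 to compound 3 (0.69 log units; beyond the scatter), and the other step is a 5.3-fold higher number from compound 1 to compound 3 (0.72 log units; beyond the scatter). Both are modest but beyond the scatter. The remaining step, a 1.1-fold higher number from compound 1 to compound 2 (0.03 log units; within the scatter), stays within the scatter, although the two groups differ widely. Within the data shown here, no measured compound carries the entering group, so the evidence is indirect. Leaving morpholin-4-yl is therefore expected to give a modest move to a lower number in this assay, of similar size to those two steps. The expected step is a 4.3-fold lower number from compound 3 to compound 4 (0.63 log units; beyond the scatter). Compound 4 is estimated at 550 nM, with an expected range of 140 nM to 2000 nM.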

Compound 4, half-maximal inhibitory concentration: > 20000 nM
Compound 4: a limit, no number (the forecaster's own chance of this, stated with the estimate: 2%); at least 36-fold (1.56 log units) between middle value and limit.
By their numbers in this assay, from the lowest: compounds 1 and 2 (each within the scatter of the next); then compound 3. At a limit, above all of these: compound 4.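

Compound 4 reads only as a limit of the assay, not as a number: the limit of > 20000 nM in this assay, at which 1 of the 4 values shown sits. The earlier compounds shown here showed only modest steps among the groups on the sulfur, whereas 5-bromo-2,3-dihydro-1H-indol-1-yl on the thiocarbonyl carbon gives an at least 8.4-fold higher number from compound 3 to compound 4 (0.92 log units; beyond the scatter), so this change moves the number upward, the opposite direction from the estimate. Within the data shown here, the gap widens against the two lower compounds, with an at least 41-fold higher number from compound 2 to compound 4 (1.61 log units; beyond the scatter) and an at least 44-fold higher number from compound 1 to compound 4 (1.64 log units; beyond the scatter), so at this place a change of group can cost far more than the earlier steps indicated.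

Going by these compounds, the true size of these steps stays open, since each ends at the limit. Also open, on these data alone, is whether the bromine atom or the rest of the entering group matters, which a plain 2,3-dihydro-1H-indol-1-yl or a piperidin-1-yl group would help to separate.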